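The source may report more compounds than this note shows. Statements on the series, on what has been measured and on what is new or still open speak of the compounds shown alone.

Compound 1 `COc1ccc2c(c1)nc1n2[C@H]2OC[C@@H](O)[C@H]2OC1` sits at the edge of what the test can report: in an ADME assay on HEp-2 cells (Homo sapiens) for cytotoxicity, read by MTT assay, with a stated time of 60 h (on this read-out higher numbers stand for lower toxicity in this test and lower numbers for higher toxicity in this test), compound 1 gives > 800000 nM, which is a limit and not a number. Compound 2 `Cc1ccc(S(=O)(=O)O[C@@H]2CO[C@H]3[C@@H]2OCc2nc4cc(Br)c(Br)cc4n23)cc1` differs from compound 1 in several places. In this assay, compound 2 gives 87500 nM. Compound 3 `COc1ccc2c(nc3n2[C@H]2OC[C@@H](O)[C@H]2OC3)c1N` has amino in place of hydrogen on an aromatic carbon of the core of compound 1 (amino in place of hydrogen on an aromatic carbon). Within the data shown here, no measured pair shows what this swap does in this assay. The estimated at least 1.6-fold lower number from compound 1 to compound 3 (0.20 log units; that floor lies within the scatter) is a modest move toward lower numbers. For compound 3, the expected value is 500000 nM, with an estimated range of 120000 nM to 1000000 nM.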

Compound 3, half-maximal cytotoxic concentration: 109000 nM
The estimate for compound 3 lay 4.6-fold (0.66 log units) above the measured number; measured number outside the range, below it.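

In this assay the amino group gives an at least 7.3-fold lower number from compound 1 to compound 3 (0.86 log units; beyond the scatter) and so supplies the first measured effect of this swap. An aromatic carbon ortho to a methoxy group is therefore a place where a single added amino group goes with higher toxicity in this test. The true size of the step stays unknown, since its starting point is a limit and the step gives only a floor: the limit of > 800000 nM in this assay, at which 1 of the 3 values shown sits.

As far as these compounds go, whether a methylamino or a hydroxyl group at this same carbon would shift the number as far remains open. So does the effect of amino elsewhere on this ring.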